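Carboxyphenyl versus carboxypyridyl cyclopropyl analogues in the bile acid receptor series

The compounds below may be only part of what the source reports. "The series", "measured", "known", "first", "only" and "open" are said of these compounds alone.

Compound 3 `O=C(O)c1cncc(C2CC2c2ccc(OCc3c(-c4c(Cl)cccc4Cl)noc3C3CC3)cc2Cl)c1` gives 103% in an assay on isolated protein for agonist activity at Bile acid receptor (Homo sapiens), read by FRET (on this read-out lower numbers stand for smaller maximal responses and higher numbers for larger maximal responses), the highest of the three numbers shown, though the steps from its neighbours, a number 1 percentage points higher from compound 2 to compound 3 (within the scatter) and a number 2 percentage points higher from compound 1 to compound 3 (within the scatter), both lie within the scatter. Compound 2 `O=C(O)c1cccc(C2CC2c2ccc(OCc3c(-c4c(Cl)cccc4Cl)noc3C3CC3)cc2Cl)c1` gives 102% and compound 1 `O=C(O)c1cccc([C@H]2C[C@@H]2c2ccc(OCc3c(-c4c(Cl)cccc4Cl)noc3C3CC3)cc2Cl)c1` gives 101% in this assay; the step of a number 1 percentage points higher from compound 1 to compound 2 (within the scatter) is likewise within the scatter, which may relate to the fact that one of compounds 1 and 2 is drawn with a defined configuration and the other without, at the place where they differ. Compound 4 `O=C(O)c1cccc([C@@H]2C[C@H]2c2ccc(OCc3c(-c4c(Cl)cccc4Cl)noc3C3CC3)cc2Cl)c1` is not yet measured. It differs from compound 3 by 2-(3-carboxyphenyl)cyclopropyl in place of 2-(5-carboxypyridin-3-yl)cyclopropyl on an aromatic carbon. The reverse of this change was seen in the step of a number 1 percentage points higher from compound 2 to compound 3 (within the scatter), and the drawn configurations of compounds 1 and 2 gave no step beyond the scatter. No shift beyond the scatter is therefore expected, a number 2 percentage points lower from compound 3 to compound 4 (within the scatter). For compound 4 the estimate in this assay is 101%, between 90% and 110%.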

Compound 4, largest response reached (reported as efficacy), in percent of the reference or control that the assay uses: 100%
The estimate for compound 4 lay 1 percentage points above the measured number; low and high end bracket the measured number.
By their numbers in this assay, from the lowest: compounds 4, 1, 2 and 3 (each within the scatter of the next).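

Inverting both saturated ring stereocentres gives a number 1 percentage points lower from compound 1 to compound 4 (within the scatter) in this assay, a direct reading on mirror images at this position: the fact that compounds 1 and 4 differ only in the configuration as drawn. Set against the form drawn without configuration, the step is a number 2 percentage points lower from compound 2 to compound 4 (within the scatter): the fact that one of compounds 2 and 4 is drawn with a defined configuration and the other without, at the place where they differ. The swap to 2-(3-carboxyphenyl)cyclopropyl from 2-(5-carboxypyridin-3-yl)cyclopropyl gives a number 3 percentage points lower from compound 3 to compound 4 (within the scatter), so it also stays within the scatter when the entering group has defined stereocentres.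

Open, as far as these compounds go, is how the maximal response would read with a primary amide in place of the carboxylic acid. Also open, from the compounds shown here alone, is the effect of a longer chain in place of the cyclopropyl ring.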